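From compound 2 to compound 4: a step behind limits

This account rests on a few compounds, and the source may have more. Where it says the series, first, only, none or still open, it means among the compounds named here.

In an ADME assay on MT4 cells (Homo sapiens) for cytotoxicity, with a stated time of 5 days (a lower number here means that less compound is tolerated, a higher number that more compound is tolerated), compound 2 (`CC(C)(C)C#Cc1cc(N(C(=O)[C@H]2CC[C@H](C)CC2)[C@H]2CC[C@@H](Oc3ccc(=O)[nH]n3)CC2)c(C(=O)O)s1`) gives > 20000 nM, which is a limit and not a number. Compound 1 (`CC(C)(C)C#Cc1cc(N(C(=O)[C@H]2CC[C@H](C)CC2)[C@H]2CC[C@H](Oc3cccnc3)CC2)c(C(=O)O)s1`) gives > 20000 nM, also a limit. Compound 3 (`CC(C)(C)C#Cc1cc(N(C(=O)[C@H]2CC[C@H](C)CC2)[C@H]2CC[C@H](OC3CCOCC3)CC2)c(C(=O)O)s1`) gives > 20000 nM, again a limit. The set therefore shows (the limit of > 20000 nM in this assay, at which 3 of the 3 values shown sit), so compound 2 has no numerical position among its neighbours.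

Compound 4 (`CC(C)(C)C#Cc1cc(N(C(=O)[C@H]2CC[C@H](C)CC2)[C@H]2CC[C@@H](Oc3cccnc3)CC2)c(C(=O)O)s1`) follows from compound 2 through one change: a group of 6 heavy atoms (5 carbon, 1 nitrogen; one six-membered aromatic ring with 1 hetero atom) in place of a group of 7 heavy atoms (4 carbon, 2 nitrogen, 1 oxygen; one six-membered aromatic ring with 2 hetero atoms), on an oxygen on a saturated carbon. Pyridin-3-yl enters on an oxygen on a saturated carbon.

Among the measured compounds shown here, the only measured step that bears on this is a step that the two limits leave unreadable from compound 1 to compound 3, which involves the same entering group at that place but gives no size to carry over. Compound 1, which also carries pyridin-3-yl, gives > 20000 nM, and this limit offers no reason to expect a fall. No step beyond the scatter is therefore expected, and the estimate is a step that the limit leaves unreadable from compound 2 to compound 4. Compound 4 is expected near 22000 nM, with an estimated range of 10000 nM to 45000 nM.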

Compound 4, half-maximal cytotoxic concentration: > 20000 nM
Compound 4: only a limit was reported (the forecaster's own chance of this, stated with the estimate: 80%); the middle value does not contradict the limit.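

Compound 4 also gives only a limit, so no step to it can be read from compound 2 or from compound 1: the limit of > 20000 nM in this assay, at which 4 of the 4 values shown sit.

The compounds shown leave open how far any of them lies beyond that limit, and whether the group on the oxygen or the configuration as drawn changes the result in this assay.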